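Working notes: lengthening the hydroxycarbamoyl chain of compound 1

This account rests on a few compounds, and the source may have more. Where it says the series, first, only, none or still open, it means among the compounds named here.

Compound 1 (`Nc1ncnc2c1c(-c1cnc3[nH]ccc3c1)nn2CC(=O)NO`) is the starting point in a functional assay on MCF7 cells (Homo sapiens) for inhibition, read by MTT assay, with a stated time of 72 h; a lower number here means a stronger inhibitor, a higher number a weaker inhibitor. In this assay compound 1 gives > 150000 nM, which is a limit of the assay and not a number. Compound 2 (`Nc1nc2cc(-c3nn(CCCC(=O)NO)c4ncnc(N)c34)ccc2o1`) gives > 50000 nM, which is also a limit. Within the data shown here, the series therefore has no measured number so far, and compound 1 cannot be ranked against compound 2.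

Compound 3 (`Nc1ncnc2c1c(-c1cnc3[nH]ccc3c1)nn2CCCCC(=O)NO`) keeps the core of compound 1 and changes only the chain: 3-(hydroxycarbamoyl)propyl in place of hydroxycarbamoyl on a saturated chain carbon bound to an aromatic nitrogen. In words, 3-(hydroxycarbamoyl)propyl stands in place of hydroxycarbamoyl on a saturated chain carbon bound to an aromatic nitrogen, so that (hydroxycarbamoyl)methyl becomes 4-(hydroxycarbamoyl)butyl.

Among the measured compounds shown here, no measured step shows what this change does. The expectation rests on compound 1 alone, with its limit of > 150000 nM. In this assay the expected step is an at least 6.0-fold lower number from compound 1 to compound 3 (0.77 log units; beyond the scatter), a moderate move towards stronger inhibition, and the result may still come back as a limit. For compound 3 the estimate is 25000 nM, with an expected range of 4000 nM to 120000 nM.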

Compound 3, half-maximal inhibitory concentration: > 150000 nM
Compound 3: no number, only a limit; the forecaster's own chance of this, stated with the estimate: 40%; at least 6.0-fold (0.77 log units) between middle value and limit.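

In this assay compound 3 gives > 150000 nM as a limit of the assay, not a number. Compound 1 also stands at a limit, so the step from compound 1 to compound 3 cannot be read: the limit of > 150000 nM in this assay, at which 2 of the 3 values shown sit.

The compounds shown leave open whether 4-(hydroxycarbamoyl)butyl in place of (hydroxycarbamoyl)methyl changes inhibition at all.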